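The compounds below may be only part of what the source reports. "The series", "measured", "known", "first", "only" and "open" are said of these compounds alone.

Working notes on the series. Compound 3 `CCNC(=O)[C@H]1O[C@@H](n2cnc3c(NNC(=O)c4cccs4)nc(Cl)nc32)[C@H](O)[C@@H]1O` in an assay on CHO cells for displacement of a labelled ligand from adenosine receptor A1 (Homo sapiens) (a lower number here means a stronger inhibitor, a higher number a weaker inhibitor), gives 737 nM. Among the numbers shown, compound 3 stands highest of the two measured values; its nearest neighbour is compound 2 `CCNC(=O)[C@H]1O[C@@H](n2cnc3c(NNC(=O)c4ccc(C)o4)ncnc32)[C@H](O)[C@@H]1O`, which in this assay gives 700 nM, a gap within the scatter. Compound 1 `CCNC(=O)[C@H]1O[C@@H](n2cnc3c(NNC(=O)c4ccccc4)ncnc32)[C@H](O)[C@@H]1O` reaches only the limit of this assay with > 5000 nM, which is a limit and not a number (the limit of > 5000 nM in this assay, at which 1 of the 3 values shown sits). Going by the values given here, the only measured step at the carbonyl carbon is an at least 7.1-fold lower number from compound 1 to compound 2 (0.85 log units; beyond the scatter), where exchanging the aryl group on that carbon moved the number beyond the scatter. Compound 4 `CCNC(=O)[C@H]1O[C@@H](n2cnc3c(NNC(=O)c4cc(-c5ccccc5)on4)nc(Cl)nc32)[C@H](O)[C@@H]1O` is not yet measured. It differs from compound 3 by 5-phenyl-1,2-oxazol-3-yl in place of thiophen-2-yl on a carbonyl carbon. The step from compound 1 to compound 2 shows that the aryl group on the carbonyl carbon can shift the number beyond the scatter, so the change to compound 4 is expected to matter as well; with the entering group larger than either measured aryl group, compound 4 is expected to give a higher number in this assay, estimated as 1500 nM (range 400 nM to 6000 nM), which means an expected step of a 2.0-fold higher number from compound 3 to compound 4 (0.31 log units; beyond the scatter).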

Compound 4, inhibition constant: > 5000 nM
Compound 4 was reported as a limit; the forecaster's own chance of this, stated with the estimate: 25%; middle value at least 3.3-fold (0.52 log units) away from the limit.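

In this assay, placing 5-phenyl-1,2-oxazol-3-yl instead of thiophen-2-yl on the carbonyl carbon gives an at least 6.7-fold higher number from compound 3 to compound 4 (0.83 log units; beyond the scatter). Going by these compounds alone, the only earlier step at this carbon lowered the number, so the aryl group here can now be seen to move the number in either direction, and this exchange on the chlorine-bearing core moves it upward. The result for compound 4 is a limit and not a number, and it joins compound 1 at that limit: the limit of > 5000 nM in this assay, at which 2 of the 4 values shown sit.

The compounds shown do not separate the contribution of the 1,2-oxazole ring from that of its phenyl group. They also leave open how the number would respond to a non-aromatic group on the carbonyl carbon, such as a short alkyl chain or a carboxylic acid.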